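The compounds below may be only part of what the source reports. "The series", "measured", "known", "first", "only" and "open" are said of these compounds alone.

Notes on the series. In a functional assay on the whole organism (strain albino) with Mus musculus as the target, with a stated time of 4 h (on this read-out higher numbers stand for an effect only at larger amounts of compound and lower numbers for an effect already at smaller amounts), compound 1 `Cc1ccccc1Nc1nnc(Nc2nc(-c3ccc(Br)cc3)cs2)s1` gives 300 mg/kg. Compound 2 `Cc1ccc(Nc2nnc(Nc3nc(-c4ccc(Br)cc4)cs3)s2)cc1` gives 300 mg/kg, and compound 3 `COc1ccccc1Nc1nnc(Nc2nc(-c3ccc(Br)cc3)cs2)s1` gives 300 mg/kg. The three measured compounds sit level at the digits shown: no change at the digits printed from compound 1 to compound 2 (within the scatter), no change at the digits printed from compound 1 to compound 3 (within the scatter) and no change at the digits printed from compound 2 to compound 3 (within the scatter) are all within the scatter. Compound 1 is level with compounds 2 and 3; nearest to it is compound 2, furthest compound 3, both without change beyond the scatter.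

Compound 4 `Cc1ccccc1Nc1nnc(Nc2nc(-c3ccc([N+](=O)[O-])cc3)cs2)s1` has not been measured. It differs from compound 1 by nitro in place of bromo on an aromatic carbon. For the measured compounds named here, the measured steps all alter the aryl group on a nitrogen on an aromatic ring, either by exchanging 4-methylphenyl or 2-methoxyphenyl for 2-methylphenyl or by putting methoxy in place of methyl on an aromatic carbon; none alters the 4-bromophenyl, so no measured step bears directly on bromo giving way to nitro. Going by the values given here, the only guidance is that three changes elsewhere in the shared core left this assay unchanged, which argues for no step beyond the scatter here either, though that rests on unrelated positions. Compound 4 is therefore expected to give 300 mg/kg, with a range from 150 mg/kg to 600 mg/kg. The expected step of no change at the digits printed from compound 1 to compound 4 (within the scatter) is none beyond the scatter.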

Compound 4, minimum effective dose: 300 mg/kg
Estimate against measurement, compound 4: no gap at the digits printed; the range from low to high includes it.
By their numbers in this assay, from the lowest: compounds 1, 2, 3 and 4 (each within the scatter of the next).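

In this assay, for the compounds shown here, the exchange of 4-bromophenyl for 4-nitrophenyl gives no change at the digits printed from compound 1 to compound 4 (within the scatter) and is the only measured change on this side of the shared core, whereas the earlier steps all altered the aryl group on the other side. The read-out therefore stays level on both sides of the core among the compounds shown. At this aromatic carbon, para to a large group, a single bromine gives way to nitro with 3 heavy atoms and hydrogen-bond acceptors that bromo lacks, and neither difference appears in the read-out. Nothing at hand speaks to what lies behind this level result.

Open, as far as these compounds go, is whether any group at this position moves the read-out beyond the scatter, for example an amine, a carboxylic acid or a longer chain such as butyl in place of bromo or nitro. Also open, from the compounds shown here alone, is whether nitro stays level when paired with the 4-methylphenyl of compound 2 or the 2-methoxyphenyl of compound 3 instead of the 2-methylphenyl of compound 4.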